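Phenethyl for Pyridyl on the Shared Core: an Expectation

A few compounds are considered here, and "the series" means these few. Any claim that something is new, unique, unknown or untested is made for them only; others in the source may bear on it.

Of the compounds shown here, three built on one shared core have been measured in an assay on Cortex for displacement of a labelled ligand from adenosine receptor A1 (Rattus norvegicus); a higher number here means a weaker inhibitor, a lower number a stronger inhibitor. Compound 1 `CCCn1c(=O)c2nc(-c3ccc(C#N)cc3)[nH]c2n(CCC)c1=O` gives 4.48 nM. Compound 2 `CCCn1c(=O)c2nc(-c3ccncc3)[nH]c2n(CCC)c1=O` gives 3.23 nM, and compound 3 `CCCn1c(=O)c2nc(-c3ccncc3)[nH]c2n(C)c1=O` gives 27.6 nM. Compound 2 has the lowest number of the three: the step of a 1.4-fold lower number from compound 1 to compound 2 (0.14 log units; within the scatter) lies within the scatter, whereas the step of an 8.5-fold higher number from compound 2 to compound 3 (0.93 log units; beyond the scatter) is a modest loss beyond it.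

Compound 4 `CCCn1c(=O)c2nc(CCc3ccccc3)[nH]c2n(CCC)c1=O` has not yet been measured in this assay. Its change from compound 2 is phenethyl in place of pyridin-4-yl on an aromatic carbon. Going by the values given here, the step from compound 1 to compound 2 shows that swapping one six-membered aromatic ring for another at this carbon left the number essentially unchanged, but no measured step involves a phenethyl group or anything other than an aromatic ring at that carbon, so the analogy is weak. The author therefore expects a step of a 9.3-fold higher number from compound 2 to compound 4 (0.97 log units; beyond the scatter) toward a higher number, modest in size, and estimates for compound 4 a value of 30 nM, within a range from 6 nM to 150 nM.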

Compound 4, inhibition constant: 57.8 nM
Compound 4: the middle estimate sits 1.9-fold (0.28 log units) below what was measured; the range from low to high includes it.
By their numbers in this assay, from the lowest: compounds 2 and 1 (each within the scatter of the next); then compound 3; then compound 4.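

Going by these compounds alone, the earlier compounds showed only that one six-membered aromatic ring could replace another on this aromatic carbon with no change beyond the scatter. Phenethyl now shows that the group here can matter in this assay, with an 18-fold higher number from compound 2 to compound 4 (1.25 log units; beyond the scatter) and a 13-fold higher number from compound 1 to compound 4 (1.11 log units; beyond the scatter), so carrying a six-membered aromatic ring is not enough to keep the number as low as those of compound 1 and compound 2. No evidence is available on what lies behind this loss. Phenethyl differs from pyridin-4-yl both in its ring, which is of carbon only, and in the saturated chain that links that ring to the core, and the compounds shown cannot separate these two changes. On these data alone, whether a directly attached phenyl, a benzyl group or an amine on this carbon would fall nearer compound 2 or compound 4 remains open.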